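The source may hold more compounds than are shown below. What is called first, only, known or untested is meant among the compounds shown, and "the series" means these compounds.

Measured so far in an ADME assay on MRC5 cells (Homo sapiens) for inhibition, read by MTT assay, with a stated time of 72 h; a higher number here means a weaker inhibitor, a lower number a stronger inhibitor:
- Compound 1 `O=C(OCCCCOC(=O)OCCc1ccc(OCc2ccccc2)c(OCc2ccccc2)c1)OCCc1ccc(OCc2ccccc2)c(OCc2ccccc2)c1`: "not determined" (no result reported)
- Compound 2 `O=C(OCCCCCCO)OCCc1ccc(O)c(O)c1`: > 50000 nM
- Compound 3 `CCCCCCCCCCCCOC(=O)OCCc1ccc(OCc2ccccc2)c(OCc2ccccc2)c1`: "not determined" (no result reported)

Only one of these three entries carries a reading at all, and even that reading is not a number. Compound 2 gives > 50000 nM, which is a limit of the assay. Its position can therefore be stated only as the limit of > 50000 nM in this assay, at which 1 of the 3 values shown sits, and the other two compounds offer no numerical comparison.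

The next compound to be tested is compound 4 `CCCCCCCCOC(=O)OCCc1ccc(O)c(O)c1`. It differs from compound 2 by one change, ethyl in place of hydroxy on a saturated chain carbon, six bonds along the chain from an oxygen next to a carbonyl group.

Among the measured compounds shown here, no measured pair shows what this change does, so the expectation is a loose one. A moderate move towards stronger inhibition in this assay is expected, though a result that again reaches the limit of the assay would be no surprise. For compound 4 the estimated value is 25000 nM. The expected range for compound 4 runs from 8000 nM to 50000 nM. The estimate corresponds to an expected shift an at least 2.0-fold lower number from compound 2 to compound 4 (0.30 log units; that floor lies within the scatter).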

Compound 4, half-maximal inhibitory concentration: 37900 nM
Compound 4: the middle estimate sits 1.5-fold (0.18 log units) below what was measured; measured number inside the range.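

In this assay, compound 4 gives the series its first single number, 37900 nM, and so shows that a reading can be obtained within the range of the assay once ethyl replaces hydroxy. This change gives an at least 1.3-fold lower number from compound 2 to compound 4 (0.12 log units; that floor lies within the scatter), so the printed step shows a direction only as a floor, and that floor does not by itself clear the usual scatter of the assay. The size of the step cannot be fixed further because compound 2 is held at a limit and not at a number: the limit of > 50000 nM in this assay, at which 1 of the 4 values shown sits.

The compounds shown leave open how large the step really is, and whether it would stand beyond the scatter if it could be read in full. They also leave open how an amine or a carboxylic acid at this position, or a longer chain, would read in this assay, so no trend along the chain can be drawn from this one pair.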